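A few compounds are considered here, and "the series" means these few. Any claim that something is new, unique, unknown or untested is made for them only; others in the source may bear on it.

Of the compounds shown here, two have been tested so far in a functional assay on UO-31 cells (Homo sapiens) for cytotoxicity, read by sulforhodamine B assay, with a stated time of 48 h, tested at 0.01 uM; on this read-out higher numbers stand for a weaker effect at the one concentration tested and lower numbers for a stronger effect. Compound 1, `COc1cc(C)cc(-c2c(-c3ccnc(-c4ccc(N(C)C)cc4)c3)cnn2CC#N)c1`, gives 63% in this assay. Among the compounds with values here, compound 2, `COc1cc(C)cc(-c2nn(CC#N)cc2-c2ccnc(-c3ccc(N(C)C)cc3)c2)c1`, gives 92% in this assay, the highest of the two numbers, and that number lies a good way above the one for compound 1, further apart than repeated measurements usually scatter. Compound 3, `Cc1cc(O)cc(-c2nn(CC#N)cc2-c2ccnc(-c3ccc(N(C)C)cc3)c2)c1`, has not yet been measured. It differs from compound 2 in one place: hydrogen in place of methyl on an oxygen on an aromatic ring, that is, methoxy becomes hydroxy, and the 3-methoxy-5-methylphenyl group becomes 3-hydroxy-5-methylphenyl. Within the data shown here, no pair of measured compounds shows this kind of change, so there is nothing to say how large a step it brings. The step from compound 2 to compound 3 is therefore expected to be small, a number 4 percentage points lower from compound 2 to compound 3 (within the scatter), most likely not beyond the usual scatter. Compound 3 is expected to give about 88% in this assay, within a range from 68% to 100%.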

Compound 3, a percentage reported as activity, at one concentration (the size of the read-out at that concentration, not a potency): 84%
Compound 3: the middle estimate sits 4 percentage points above what was measured; the measured number falls inside the stated range.
By their numbers in this assay, from the lowest: compound 1; then compounds 3 and 2 (each within the scatter of the next).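

Within the data shown here, the change from methoxy to hydroxy on the aromatic ring gives a number 8 percentage points lower from compound 2 to compound 3 (within the scatter) in this assay and so provides the first reading of this change. On the structure shared by these two compounds, the methyl on this oxygen can therefore be replaced by hydrogen without a shift that this single-concentration test can separate from ordinary scatter. No measurement shown here gives an explanation for this result.

From the compounds shown here alone, whether a longer chain such as ethoxy on the same oxygen, or an amine in place of the hydroxy group, would move the read-out beyond the scatter remains open. Also open, going by these compounds, is whether the same change from methoxy to hydroxy would have a similarly small effect on the core of compound 1.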